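A few compounds are considered here, and "the series" means these few. Any claim that something is new, unique, unknown or untested is made for them only; others in the source may bear on it.

Measured compounds:
- Compound 1, `COc1ccc(-n2cc(CSC(=S)N3CCN(C(=O)OC(C)(C)C)CC3)nn2)cc1`: in a functional assay on MGC-803 cells (Homo sapiens) for inhibition, read by MTT assay, with a stated time of 72 h (a lower number here means a stronger inhibitor, a higher number a weaker inhibitor), compound 1 gives 87300 nM.
- Compound 2, `S=C(SCc1cn(Cc2ccc(Cl)c(Cl)c2)nn1)N1CCNCC1`: in this assay compound 2 gives "not determined" (no result reported), so no result is reported for it.

Compound 2 stands nowhere on the numbers shown: for it there is no value, and so no single number from which a step could be counted. Within the data shown here, the only anchor is compound 1, which shares with compound 3 the tert-butoxycarbonyl on the ring nitrogen and the dithiocarbamate linkage to the triazole, but carries a different substituent on the triazole nitrogen.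

Compound 3, `CC(C)(C)OC(=O)N1CCN(C(=S)SCc2cn(Cc3ccc(Cl)c(Cl)c3)nn2)CC1`, differs from compound 2 by tert-butoxycarbonyl in place of hydrogen on an amine nitrogen in a ring. Compound 2 has no number in this assay, and no direction or size can be read for this step from the measured pair. What can be said is that the closest measured relative of compound 3 is compound 1, which gives 87300 nM, a weak result.

On that basis compound 3 is expected to land at roughly 20000 nM, with a plausible range from 3000 nM to 110000 nM.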

Compound 3, half-maximal inhibitory concentration: 33700 nM
For compound 3 the middle estimate is 1.7-fold (0.23 log units) below the measured one; the range from low to high includes it.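

In this assay, 3,4-dichlorobenzyl in place of 4-methoxyphenyl on an aromatic nitrogen, with the tert-butoxycarbonyl and the rest of the core unchanged, gives a 2.6-fold lower number from compound 1 to compound 3 (0.41 log units; beyond the scatter). This shows that the read-out responds to a change at this position, although the step is modest and compound 3, at 33700 nM, remains a weak inhibitor. The step from hydrogen to tert-butoxycarbonyl on the amine nitrogen in a ring cannot be read, as compound 2 has no number, and nothing at hand accounts for the difference seen at the aromatic nitrogen.

This single step replaces one whole group with another, so the compounds shown do not separate any contribution of the two chlorines from that of the benzyl frame; a plain benzyl or a 4-chlorobenzyl on the aromatic nitrogen would bear on that question. From the compounds shown here alone, what a small group such as acetyl or methyl on the amine nitrogen in a ring would do to the value also stays open, as does whether the step seen here would hold with anything other than tert-butoxycarbonyl there.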